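The source may report more compounds than this note shows. Statements on the series, on what has been measured and on what is new or still open speak of the compounds shown alone.

Three measured compounds and one unmeasured compound share a core. In a functional assay on DU-145 cells (Homo sapiens) for cytotoxicity, read by MTT assay, with a stated time of 48 h (on this read-out lower numbers stand for stronger inhibition and higher numbers for weaker inhibition), compound 1 `CCOC(=O)c1c(-c2cc3ccccc3oc2=O)nn(-c2ccccc2)c1C(=O)OCC` gives 57000 nM. Compound 2 `CCOC(=O)c1c(-c2cc3ccccc3oc2=O)nn(-c2cccc(Cl)c2)c1C(=O)OCC` gives 35000 nM in this assay; the two cores differ by hydrogen in place of chloro on an aromatic carbon. Compound 3 `CCOC(=O)c1c(-c2cc3cc(OC)ccc3oc2=O)nn(-c2cccc(Cl)c2)c1C(=O)OCC` gives 29000 nM in this assay. The change from compound 2 to compound 3 is methoxy in place of hydrogen on an aromatic carbon, and it made a 1.2-fold lower number from compound 2 to compound 3 (0.08 log units; within the scatter). Compound 4 `CCOC(=O)c1c(-c2cc3ccc(OC)cc3oc2=O)nn(-c2ccccc2)c1C(=O)OCC` has not yet been measured; it arises from compound 1 by the same change, (methoxy in place of hydrogen on an aromatic carbon), at the same place on the ring. Because the measured step of a 1.2-fold lower number from compound 2 to compound 3 (0.08 log units; within the scatter) stayed within the scatter, the step expected for compound 4 is a 1.1-fold lower number from compound 1 to compound 4 (0.06 log units; within the scatter). In this assay compound 4 is estimated at 50000 nM, most likely between 25000 nM and 100000 nM.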

Compound 4, half-maximal inhibitory concentration: 33000 nM
The estimate for compound 4 lay 1.5-fold (0.18 log units) above the measured number; measured number inside the range.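

In this assay, methoxy in place of hydrogen on an aromatic carbon gives a 1.7-fold lower number from compound 1 to compound 4 (0.24 log units; within the scatter), a step that stays within the usual scatter. Set beside the earlier step on the other core, the two results agree: the same change on two cores in this assay, a 1.2-fold lower number (0.08 log units; within the scatter) from compound 2 to compound 3 and a 1.7-fold lower number (0.24 log units; within the scatter) from compound 1 to compound 4, 1.4-fold (0.16 log units) apart, within the scatter of two such steps

This shows that the change carried over to a second core without a step beyond the scatter, but it does not show that methoxy truly alters the number on either core, and two cores cannot establish a rule for the whole series.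

The compounds shown leave open whether a different group on this ring, such as an amine or a carboxylic acid, would give a step beyond the scatter. They also leave open what a longer chain in place of methoxy would do.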